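Replacing (furan-2-yl)methyl with 4-chloropyridin-2-yl

The source may report more compounds than this note shows. Statements on the series, on what has been measured and on what is new or still open speak of the compounds shown alone.

In an ADME assay on L02 cells (Homo sapiens) for inhibition, read by CCK-8 assay, with a stated time of 48 h (on this read-out higher numbers stand for weaker inhibition of growth and lower numbers for stronger inhibition of growth), compound 1 (`Cc1ccc(Nc2ncc(Cl)c(Nc3ccccc3C)n2)cc1`) gives > 100000 nM, which is a limit of the assay and not a number. Compound 2 (`Cc1ccccc1Nc1nc(NCc2ccco2)ncc1Cl`) gives > 100000 nM, which is also a limit. Within the data shown here, the only measured change is a step that the two limits leave unreadable from compound 1 to compound 2, so no size can be carried forward. Compound 3 (`Cc1ccccc1Nc1nc(Nc2cc(Cl)ccn2)ncc1Cl`) differs from compound 2 as follows: 4-chloropyridin-2-yl in place of (furan-2-yl)methyl on a nitrogen on an aromatic ring. Given (the limit of > 100000 nM in this assay, at which 2 of the 2 values shown sit), the expected change is an at least 1.6-fold lower number from compound 2 to compound 3 (0.22 log units; that floor lies within the scatter), perhaps none beyond the scatter, and towards stronger inhibition if any. Compound 3 is estimated at 60000 nM, with an expected range of 15000 nM to 100000 nM.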

Compound 3, concentration for 50% growth inhibition: 41500 nM
The estimate for compound 3 lay 1.4-fold (0.16 log units) above the measured number, within the range that was stated.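

In this assay, putting 4-chloropyridin-2-yl on this nitrogen brings a measurable effect on growth, towards stronger inhibition, with an at least 2.4-fold lower number from compound 2 to compound 3 (0.38 log units; beyond the scatter). The same group also compares favourably with 4-methylphenyl at this place, with an at least 2.4-fold lower number from compound 1 to compound 3 (0.38 log units; beyond the scatter). Both steps are floors rather than full sizes, so the true gaps may be larger: the limit of > 100000 nM in this assay, at which 2 of the 3 values shown sit.

The compounds shown leave open whether the chlorine or the ring nitrogen of 4-chloropyridin-2-yl matters here. From the compounds shown here alone, how an amine or a carboxylic acid on that ring would move the number is also open.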